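Moving the chlorine on the ring: compound 2 to compound 3

The source may hold more compounds than are shown below. What is called first, only, known or untested is meant among the compounds shown, and "the series" means these compounds.

Compound 2 `O=C(COCc1ccccc1)N1CCN(c2ccccc2Cl)CC1` was tested in a functional assay on HEK293 cells for positive allosteric modulation of metabotropic glutamate receptor 5 (Homo sapiens), read by FLIPR and calcium flux (on this read-out higher numbers stand for an effect only at larger amounts of compound and lower numbers for an effect already at smaller amounts), and gives 1100 nM. Among the two compounds measured so far, this is the lowest number, and the only neighbour is compound 1 `O=C(COCc1ccccc1)N1CCN(c2ccccc2)CC1`, which in this assay gives 7100 nM. Within the data shown here, the single step between them, a 6.5-fold lower number from compound 1 to compound 2 (0.81 log units; beyond the scatter), is the change of a hydrogen on an aromatic carbon into a chlorine.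

Compound 3 `O=C(COCc1ccccc1)N1CCN(c2cccc(Cl)c2)CC1` keeps every atom of compound 2 but joins them differently: 3-chlorophenyl in place of 2-chlorophenyl on an amine nitrogen in a ring. The chlorine stays on the same ring yet sits at another carbon of it.

Among the measured compounds shown here, no measured step addresses such a relocation of a chlorine; the only step on hand, a 6.5-fold lower number from compound 1 to compound 2 (0.81 log units; beyond the scatter), concerns adding the chlorine rather than moving it. With the chlorine retained, compound 3 is expected to sit between compound 1 and compound 2, and a step of a 2.3-fold higher number from compound 2 to compound 3 (0.36 log units; beyond the scatter) in this assay is estimated. For compound 3 the value in this assay is estimated at 2500 nM, with a range from 800 nM to 8000 nM.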

Compound 3, half-maximal effective concentration: 6700 nM
Compound 3: middle estimate off by 2.7-fold (0.43 log units), on the low side; the range from low to high includes it.
By their numbers in this assay, from the lowest: compound 2; then compounds 3 and 1 (each within the scatter of the next).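

Where the chlorine sits on the ring matters in this assay: moving it from the 2-chlorophenyl to the 3-chlorophenyl arrangement gives a 6.1-fold higher number from compound 2 to compound 3 (0.78 log units; beyond the scatter), although the atoms stay the same. The 3-chlorophenyl group also brings no gain that can be read over the plain phenyl group, with a 1.1-fold lower number from compound 1 to compound 3 (0.03 log units; within the scatter), so the earlier improvement cannot be credited to the presence of a chlorine alone; among these three compounds, it appears only with the 2-chlorophenyl group. Nothing available explains this difference between the two chlorine placements.

From the compounds shown here alone, it remains open whether the number depends on chlorine itself or whether a fluorine, a methyl group or a methoxy group in the place of the chlorine in the 2-chlorophenyl group would give a similar result. These compounds also share the rest of their structure, so they cannot show whether the same preference for the 2-chlorophenyl group would hold if the far phenyl ring were replaced by a pyridine.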